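A few compounds are considered here, and "the series" means these few. Any claim that something is new, unique, unknown or untested is made for them only; others in the source may bear on it.

Measured in a functional assay on MCF7 cells (Homo sapiens) for cytotoxicity, read by MTT assay, with a stated time of 48 h; on this read-out lower numbers stand for stronger inhibition and higher numbers for weaker inhibition:
compound 1 `CCN(CC)C(=S)SC(CC(=O)c1ccc(OC)cc1)c1ccccc1`: 4500 nM
compound 2 `CCN(CC)C(=S)SC(CC(=O)c1ccc(OC)cc1)c1ccc(OC)cc1`: 800 nM
compound 3 `CCN(CC)C(=S)SC(CC(=O)c1ccc(OC)cc1)c1ccc(C)cc1`: 17000 nM

Compound 3 gives the highest number of the three in this assay, and its steps to both others lie beyond the scatter, so it is the weakest so far. The change under consideration leads to compound 4 `CCN(CC)C(=S)SC(CC(=O)c1ccc(OC)cc1)c1ccccc1Cl`: 2-chlorophenyl in place of 4-methylphenyl on a saturated chain carbon bound to a saturated chain carbon and a sulfur. Going by the values given here, no measured compound carries the 2-chlorophenyl group, so the measured steps bear on this change only indirectly. The closest guide is a 3.8-fold higher number from compound 1 to compound 3 (0.58 log units; beyond the scatter), a modest step that involves the same methyl group that leaves here. The modest 5.6-fold lower number from compound 1 to compound 2 (0.75 log units; beyond the scatter) and the large 21-fold higher number from compound 2 to compound 3 (1.33 log units; beyond the scatter) show how far changes on this aromatic ring have moved the number. A modest fall in this assay is therefore expected, towards the level of compound 1, with a wide margin. The expected step is a 3.4-fold lower number from compound 3 to compound 4 (0.53 log units; beyond the scatter). For compound 4 the estimated value is 5000 nM, with an expected range of 1300 nM to 20000 nM.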

Compound 4, half-maximal inhibitory concentration: 70 nM
Compound 4: the middle estimate sits 71-fold (1.85 log units) above what was measured; the whole stated range lies above it.
By their numbers in this assay, from the lowest: compound 4; then compound 2; then compound 1; then compound 3.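

In this assay, going by these compounds alone, the group on the saturated chain carbon bound to a saturated chain carbon and a sulfur spans a far wider range than the earlier compounds showed: 2-chlorophenyl in place of 4-methylphenyl gives the largest step (a 240-fold lower number from compound 3 to compound 4 (2.39 log units; beyond the scatter)) and also surpasses the best earlier group (an 11-fold lower number from compound 2 to compound 4 (1.06 log units; beyond the scatter)). The added chloro group (a 64-fold lower number from compound 1 to compound 4 (1.81 log units; beyond the scatter)) makes compound 4 the strongest of the four and reverses the ranking in which 4-methoxyphenyl led. No measurement here explains this gain.

Going by these compounds, whether the gain follows the chlorine or its place on the ring stays open; 4-chlorophenyl and 2-methylphenyl would separate the two. Also open, on these data alone, is whether it survives a pyrrolidine in place of the diethylamino group.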